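The source may report more compounds than this note shows. Statements on the series, on what has been measured and on what is new or still open speak of the compounds shown alone.

Measured so far:
compound 1, `CC(C)n1nc(-c2cccnc2)c2ccccc2c1=O`: 87%
compound 2, `O=c1c2ccccc2c(-c2cccnc2)nn1CC1CCCCC1`: 98%

In an assay on isolated protein (Oryctolagus cuniculus) with Thromboxane-A synthase (Homo sapiens) as the target, tested at 1 uM (on this read-out higher numbers stand for more inhibition at the one concentration tested (going by the name of the read-out) and lower numbers for less inhibition), compound 2 gives the higher of the two numbers; its nearest neighbour is compound 1, and the step of a number 11 percentage points higher from compound 1 to compound 2 (beyond the scatter) lies beyond the usual scatter of such measurements. Compound 3, `O=c1c2ccccc2c(-c2cccnc2)nn1Cc1cccc(Cl)c1`, has not yet been measured. It differs from compound 2 by 3-chlorophenyl in place of cyclohexyl on a saturated chain carbon bound to an aromatic nitrogen. Going by the values given here, no measured step involves this same change; the single step known, a number 11 percentage points higher from compound 1 to compound 2 (beyond the scatter), concerns a different exchange, cyclohexylmethyl in place of isopropyl, and so offers only a rough guide to how much this part of the molecule can be altered. Because compound 2 already gives 98%, little room remains upward, and a step no larger than the scatter, most likely slightly downward, is expected, a number 6 percentage points lower from compound 2 to compound 3 (within the scatter). Compound 3 is therefore estimated at 92%, with a range from 72% to 99%.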

Compound 3, a percentage reported as inhibition, at one concentration (the size of the read-out at that concentration, not a potency): 95%
Estimate against measurement, compound 3: 3 percentage points below, and the stated range covers the measured number.
By their numbers in this assay, from the lowest: compounds 1, 3 and 2 (each within the scatter of the next, the first and the last beyond it).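

In this assay, replacing the saturated ring with an aromatic one carrying chlorine gives a number 3 percentage points lower from compound 2 to compound 3 (within the scatter), so this position accepts either 3-chlorophenyl or cyclohexyl on the saturated chain carbon without a change that can be told from the scatter. Measured against the isopropyl group, 3-chlorobenzyl gives a number 8 percentage points higher from compound 1 to compound 3 (within the scatter), while cyclohexylmethyl gives a number 11 percentage points higher from compound 1 to compound 2 (beyond the scatter), so only the second of these replacements separates clearly from compound 1. Nothing available explains why the two ring groups read alike.

Going by these compounds, it remains open how a plain benzyl group, without chlorine, or a carboxylic acid on a longer chain would read at this position. A single-concentration read-out this close to the top of its scale also leaves any real difference between compound 2 and compound 3 unresolved.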